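Methoxy for chloro on the benzylamine arm

The source may report more compounds than this note shows. Statements on the series, on what has been measured and on what is new or still open speak of the compounds shown alone.

Compound 2 `COc1cc(Oc2cccc(Nc3ccccc3)c2)cc(OC)c1CNCc1ccc(Cl)cc1` gives 6340 nM in a functional assay on SW-620 cells (Homo sapiens) for inhibition, read by MTT assay, with a stated time of 72 h; on this read-out lower numbers stand for stronger inhibition and higher numbers for weaker inhibition. Compound 1 `COc1cc(Oc2cccc(Nc3ccccc3)c2)cc(OC)c1CNCc1ccc(Br)cc1` gives 11200 nM, and compound 3 `COc1cc(Oc2cccc(Nc3ccccc3)c2)cc(OC)c1CNCc1ccc(C)cc1` gives 11800 nM. The three steps, a 1.8-fold lower number from compound 1 to compound 2 (0.25 log units; within the scatter), a 1.1-fold higher number from compound 1 to compound 3 (0.02 log units; within the scatter) and a 1.9-fold higher number from compound 2 to compound 3 (0.27 log units; within the scatter), all stay within the scatter, so compound 2 holds the smallest of three numbers that cannot be told apart. Compound 4 `COc1ccc(CNCc2c(OC)cc(Oc3cccc(Nc4ccccc4)c3)cc2OC)cc1` differs from compound 2 by methoxy in place of chloro on an aromatic carbon. Within the data shown here, no measured step exchanges chloro for methoxy; the bromo, chloro and methyl variants bear on it only by showing that changes on that aromatic carbon have not moved this assay beyond the scatter. A step of no more than the scatter is therefore expected, a 1.3-fold higher number from compound 2 to compound 4 (0.13 log units; within the scatter). Compound 4 is estimated at 8500 nM, within 3000 nM to 25000 nM.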

Compound 4, half-maximal inhibitory concentration: 6970 nM
Beside the measured number, compound 4's estimate is 1.2-fold (0.09 log units) above it; the range from low to high includes it.
By their numbers in this assay, from the lowest: compounds 2, 4, 1 and 3 (each within the scatter of the next).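

With methoxy, an oxygen-linked group and one hydrogen-bond acceptor enter on this aromatic carbon, yet the exchange for chloro gives a 1.1-fold higher number from compound 2 to compound 4 (0.04 log units; within the scatter) and stays within the scatter. The other two steps, a 1.7-fold lower number from compound 3 to compound 4 (0.23 log units; within the scatter) and a 1.6-fold lower number from compound 1 to compound 4 (0.21 log units; within the scatter), are also within the scatter, so the four groups at this position cannot be told apart in this assay and the flat picture now extends to an oxygen-linked group. Nothing available explains this flatness.

Open, from the compounds shown here alone, is whether a carboxylic acid, an amine or a longer chain at this position would move the number beyond the scatter. Also open, going by these compounds, is whether the flat picture holds with no group on this carbon.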